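Replacing a tert-Butyl Group: Expectation for Compound 4

A few compounds are considered here, and "the series" means these few. Any claim that something is new, unique, unknown or untested is made for them only; others in the source may bear on it.

Three compounds have been measured in a functional assay on NCI-H520 cells (Homo sapiens) for inhibition, read by MTT assay, with a stated time of 48 h, tested at 10 uM; on this read-out higher numbers stand for more inhibition at the one concentration tested (going by the name of the read-out) and lower numbers for less inhibition:
compound 1, `COc1cc(NC(=O)Nc2cc(Nc3ccc(OC)c(C)c3)ncn2)cc(OC)c1`, gives 13.5%;
compound 2, `COc1cc(NC(=O)Nc2cc(Nc3ccc(C)c(F)c3)ncn2)cc(OC)c1`, gives 30.6%;
compound 3, `COc1cc(NC(=O)Nc2cc(Nc3cccc(C(C)(C)C)c3)ncn2)cc(OC)c1`, gives 13.1%.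

Compound 3 stands lowest of the three numbers, though only the gap to compound 2 counts: the step of a number 0.4 percentage points lower from compound 1 to compound 3 (within the scatter) lies within the scatter, whereas a number 17.5 percentage points lower from compound 2 to compound 3 (beyond the scatter) is beyond it and modest in size. The remaining step, a number 17.1 percentage points higher from compound 1 to compound 2 (beyond the scatter), shows that among these three the 3-fluoro-4-methylphenyl group is the one that lifts inhibition.

Compound 4, `COc1cc(NC(=O)Nc2cc(Nc3cc(C)cc(F)c3)ncn2)cc(OC)c1`, is the next step from compound 3: 3-fluoro-5-methylphenyl in place of 3-(tert-butyl)phenyl on a nitrogen on an aromatic ring. The measured step that bears most on this change is a number 17.5 percentage points lower from compound 2 to compound 3 (beyond the scatter), run in reverse, since the tert-butyl group is again exchanged for a phenyl carrying one fluorine and one methyl. The arrangement in compound 4, 3-fluoro-5-methylphenyl, is not the same as in compound 2, so the full size of that step need not return. A rise in this assay of modest size is therefore expected, with the step estimated as a number 9.9 percentage points higher from compound 3 to compound 4 (within the scatter). The estimate for compound 4 is 23%, expected to fall between 8% and 40%.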

Compound 4, a percentage reported as inhibition, at one concentration (the size of the read-out at that concentration, not a potency): 24.5%
Compound 4: middle estimate off by 1.5 percentage points, on the low side, within the range that was stated.
By their numbers in this assay, from the lowest: compounds 3 and 1 (each within the scatter of the next); then compounds 4 and 2 (each within the scatter of the next).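

In this assay the step of a number 11.4 percentage points higher from compound 3 to compound 4 (beyond the scatter) and the step of a number 11 percentage points higher from compound 1 to compound 4 (beyond the scatter) show that 3-fluoro-5-methylphenyl, on a nitrogen on an aromatic ring, stands clear of both 3-(tert-butyl)phenyl and 4-methoxy-3-methylphenyl, so the higher reading of compound 2 no longer stands alone among the groups at this position. Among these compounds, the change from 3-fluoro-4-methylphenyl to 3-fluoro-5-methylphenyl gives a number 6.1 percentage points lower from compound 2 to compound 4 (within the scatter), so the two arrangements of fluorine and methyl cannot be told apart here, and across the four compounds both of them read apart from the other two groups, with no compound going against this. Nothing at hand explains why these groups differ at this position.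

The compounds shown leave open whether the fluorine or the methyl matters more, as a phenyl carrying only a fluorine or only a methyl would have to be read to separate them. They also leave open how a phenyl bearing an amine, a carboxylic acid or a longer chain would read at this place, and how these single-concentration readings relate to potency.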